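Replacing Isopropyl With 3-Methoxyphenyl on the Imidazole Nitrogen

The source may report more compounds than this note shows. Statements on the series, on what has been measured and on what is new or still open speak of the compounds shown alone.

Measured compounds:
Compound 1 `COc1cc(-c2nccn2C(C)C)cc(OC)c1OC`: > 100000 nM
Compound 2 `COc1cc(-c2nccn2-c2ccc3cc[nH]c3c2)cc(OC)c1OC`: 7500 nM

The shared core of compound 1 carries an isopropyl group on one ring nitrogen. In a functional assay on MDA-MB-231 cells (Homo sapiens) for antiproliferative activity, read by MTT assay, with a stated time of 72 h (on this read-out higher numbers stand for weaker inhibition and lower numbers for stronger inhibition), compound 1 gives > 100000 nM, which is a limit of the assay and not a number, so its true value is known only as the limit of > 100000 nM in this assay, at which 1 of the 2 values shown sits. Compound 2 gives 7500 nM in this assay, a measured number rather than a limit. Compound 3 `COc1cccc(-n2ccnc2-c2cc(OC)c(OC)c(OC)c2)c1` is the compound under question. It differs from compound 1 in one place: 3-methoxyphenyl in place of isopropyl on an aromatic nitrogen. Within the data shown here, no step between measured compounds is available to rest on, so the expectation for the step in this assay comes from the change itself and from the two values shown. A move from the limit of compound 1 toward a measurable number is expected, in the direction of stronger inhibition, beyond the usual scatter. Compound 3 is therefore estimated to give 5000 nM in this assay, within a range of 800 nM to 30000 nM, which corresponds to an expected step of an at least 20-fold lower number from compound 1 to compound 3 (1.30 log units; beyond the scatter).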

Compound 3, half-maximal inhibitory concentration: 18300 nM
Estimate against measurement, compound 3: 3.7-fold (0.56 log units) below; measured number inside the range.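

In this assay, the place on the aromatic nitrogen accepts a 3-methoxyphenyl group in place of isopropyl, and the change gives an at least 5.4-fold lower number from compound 1 to compound 3 (0.73 log units; beyond the scatter). Compound 3 gives 18300 nM, a measured number, so this single swap is enough to bring the shared core from an unmeasurable level of inhibition into the range the assay can read, which no step between measured compounds had shown before. The step has a lower bound but no full size, because compound 1 carries a limit of the assay and not a number: the limit of > 100000 nM in this assay, at which 1 of the 3 values shown sits.

The compounds shown do not separate what the aromatic ring contributes from what its methoxy group contributes, and a plain phenyl group on this nitrogen would make that split readable. From the compounds shown here alone, how a group of another kind at the same place, such as an amine, a carboxylic acid or a longer alkyl chain, would read in this assay also remains open, so no trend across this position can yet be drawn from these compounds.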